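The compounds below may be only part of what the source reports. "The series", "measured", "known", "first", "only" and "open" are said of these compounds alone.

Measured in an assay on isolated protein for inhibition of protein deacetylase HDAC6 (Homo sapiens), read by fluorescence, with stated times of 10 min and 30 min, tested at 10 uM; on this read-out lower numbers stand for less inhibition and higher numbers for more inhibition at the one concentration tested (going by the name of the read-out):
compound 1 `CCOc1cc(NC(=O)CCCCCNC(=O)CCCc2ccccc2)cc2c1OCC([N+](=O)[O-])=C2`: 43%
compound 2 `CCOc1cc(NC(=O)CCCCCC(=O)Nc2cc(-c3ccc(C)s3)ccc2N)cc2c1OCC([N+](=O)[O-])=C2`: 36%
compound 3 `CCOc1cc(NC(=O)CCCCC(=O)Nc2cc(-c3ccccc3)ccc2N)cc2c1OCC([N+](=O)[O-])=C2`: 25%

Compound 2 sits in the middle of the three numbers: its value and that of compound 1 lie within the usual scatter of each other, while compound 3 lies lower by a margin beyond the scatter. Compound 4 `CCOc1cc(NC(=O)CCCCCC(=O)Nc2cc(-c3ccccc3)ccc2N)cc2c1OCC([N+](=O)[O-])=C2` differs from compound 2 in one place: phenyl in place of 5-methylthiophen-2-yl on an aromatic carbon. Going by the values given here, no measured pair shows this change on its own. Compound 3 also carries a phenyl at that carbon and gives 25%, the lowest of the three, so a modest drop from compound 2 in this assay is expected, possibly still within the scatter. Compound 4 is estimated at 30% (range 15% to 45%), which means an expected step of a number 6 percentage points lower from compound 2 to compound 4 (within the scatter).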

Compound 4, a percentage reported as inhibition, at one concentration (the size of the read-out at that concentration, not a potency): 28%
Compound 4: the middle estimate sits 2 percentage points above what was measured; low and high end bracket the measured number.
By their numbers in this assay, from the lowest: compounds 3, 4, 2 and 1 (each within the scatter of the next, the first and the last beyond it).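

In this assay the change taken on its own gives a number 8 percentage points lower from compound 2 to compound 4 (within the scatter) and so does not separate phenyl from 5-methylthiophen-2-yl on this aromatic carbon, para to an amino group. At this position, a six-membered aromatic ring of carbon only and a five-membered one with a sulfur atom therefore read alike at the one concentration tested. Nothing available gives a reason for this result.

As far as these compounds go, whether an amine or a carboxylic acid on the phenyl would shift the read-out remains open. So does whether a pyridine ring at this carbon would read alike.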